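A New Heterocycle at the End of the Ether Chain

The source may hold more compounds than are shown below. What is called first, only, known or untested is meant among the compounds shown, and "the series" means these compounds.

Three compounds share a common core and differ at the ether-linked tail or at the aryl ring. Compound 1 `CCO/C(O)=C1\C(COCCn2cc(C(N)=O)nn2)=NC(C)=C(C(=O)OC)C1c1cccc(Cl)c1Cl` gives 3.16 nM in a functional assay (aorta) with Rattus norvegicus as the target; on this read-out higher numbers stand for weaker inhibition and lower numbers for stronger inhibition. Compound 2 `CCO/C(O)=C1\C(COCCn2ccnn2)=NC(C)=C(C(=O)OC)C1c1cccc(Cl)c1Cl` gives 5.01 nM in this assay, a change of a 1.6-fold higher number from compound 1 to compound 2 (0.20 log units; within the scatter). Compound 3 `CCO/C(O)=C1\C(COCCn2cc(C(N)=O)nn2)=NC(C)=C(C(=O)OC)C1c1ccccc1Cl` gives 20 nM in this assay, the highest of the three numbers, and the step from compound 1 is a 6.3-fold higher number from compound 1 to compound 3 (0.80 log units; beyond the scatter).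

Compound 4 `CCO/C(O)=C1\C(COCCn2cc(N)nc2O)=NC(C)=C(C(=O)OC)C1c1ccccc1Cl` carries 4-amino-2-hydroxy-1H-imidazol-1-yl in place of 4-carbamoyl-1H-1,2,3-triazol-1-yl on a saturated chain carbon, two bonds along the chain from an oxygen on a saturated carbon. Among the measured compounds shown here, the only measured step touching the tail ring, a 1.6-fold higher number from compound 1 to compound 2 (0.20 log units; within the scatter), changed just one substituent on it and stayed within the scatter; no measured step exchanges the ring itself, so the present change is beyond what the data directly cover. Compound 4 is therefore expected to sit near compound 3, with the step of a 1.3-fold higher number from compound 3 to compound 4 (0.10 log units; within the scatter) estimated as small but carrying a wide range. The estimate for compound 4 in this assay is 25 nM, expected between 8 nM and 80 nM.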

Compound 4, half-maximal inhibitory concentration: 31.6 nM
The estimate for compound 4 lay 1.3-fold (0.10 log units) below the measured number; the measured number falls inside the stated range.
By their numbers in this assay, from the lowest: compounds 1 and 2 (each within the scatter of the next); then compounds 3 and 4 (each within the scatter of the next).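

Among the compounds shown here, compound 4 provides the first measured exchange of the tail ring itself, rather than of one substituent on it. In this assay, placing 4-amino-2-hydroxy-1H-imidazol-1-yl in place of 4-carbamoyl-1H-1,2,3-triazol-1-yl on a saturated chain carbon, two bonds along the chain from an oxygen on a saturated carbon, gives a 1.6-fold higher number from compound 3 to compound 4 (0.20 log units; within the scatter), so at this position and with this aryl ring the two different heterocycles cannot be told apart. No evidence is available that bears on this result.

The compounds shown leave open whether the same exchange would read alike on the dichlorophenyl-bearing core of compound 1. They also leave open how a carboxylic acid on the tail ring, or a longer chain between the ether oxygen and the ring, would read at this position.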